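A few compounds are considered here, and "the series" means these few. Any claim that something is new, unique, unknown or untested is made for them only; others in the source may bear on it.

Series notes. Compound 1 `CC(=O)NC12CCCC3CC(CCC31)C2` in an ADME assay (Gallus gallus) for cytotoxicity, read by microscopy, with a stated time of 24 h (on this read-out lower numbers stand for higher toxicity in this test and higher numbers for lower toxicity in this test), gives 3000000 nM. Going by the values given here, compound 2 `OCC12CCCC3CC(CCC31)C2` in this assay gives 870000 nM; the step of a 3.4-fold lower number from compound 1 to compound 2 (0.54 log units; beyond the scatter) is the only measured step in the set. Compound 3 `O=C(Cl)C12CCCC3CC(CCC31)C2` in this assay gives no result reported and so stands nowhere on the numbers shown. Compound 4 `N#CC12CCCC3CC(CCC31)C2` differs from compound 3 as follows: a group of 2 heavy atoms (1 carbon, 1 nitrogen; no ring) in place of a group of 3 heavy atoms (1 carbon, 1 oxygen, 1 chlorine; no ring), on a saturated ring carbon. Among the compounds with values here, no measured step bears on this change: the one step available concerns hydroxymethyl in place of acetamido and gives no guide to cyano in place of the group that leaves. With no anchor value for compound 3, the expectation for compound 4 can rest only on the spread between compound 1 and compound 2 in this assay. Compound 4 is therefore estimated at 1500000 nM, with an expected range from 300000 nM to 6000000 nM.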

Compound 4, minimum cytotoxic concentration: 850000 nM
Compound 4: the middle estimate sits 1.8-fold (0.25 log units) above what was measured; the range from low to high includes it.
By their numbers in this assay, from the lowest: compounds 4 and 2 (each within the scatter of the next); then compound 1.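

In this assay cyano on this saturated ring carbon reads level with hydroxymethyl (a 1.0-fold lower number from compound 2 to compound 4 (0.01 log units; within the scatter)), so these two groups are not told apart here. Against acetamido, the same place gives a 3.5-fold lower number from compound 1 to compound 4 (0.55 log units; beyond the scatter) and compound 1 now stands apart from two compounds rather than one. No measured evidence bears on the cause of either step. Still open, from the compounds shown here alone, is whether an amine, a carboxylic acid or a longer chain at this place would read with compound 1 or with compound 2 and compound 4.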